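The compounds below may be only part of what the source reports. "The series", "measured", "known", "first", "only" and "open" are said of these compounds alone.

Measured compounds:
compound 1, `CC1=C(C(=O)Nc2ccc(Br)cn2)C(c2cn(-c3ccccc3)nc2-c2ccccc2)n2ncnc2N1`: 25 ug/mL
compound 2, `CC1=C(C(=O)Nc2ccc(Br)cn2)C(c2cn(-c3ccccc3)nc2-c2ccc([N+](=O)[O-])cc2)n2ncnc2N1`: 25 ug/mL

In an ADME assay on Vero cells (Chlorocebus sabaeus) for cytotoxicity, read by MTT assay, with a stated time of 72 h (on this read-out higher numbers stand for lower toxicity in this test and lower numbers for higher toxicity in this test), compound 2 gives 25 ug/mL, level with compound 1 at the digits shown; the step of no change at the digits printed from compound 1 to compound 2 (within the scatter) is within the scatter. Compound 3, `CC1=C(C(=O)Nc2ccc(Br)cn2)C(c2cn(-c3ccccc3)nc2-c2ccc(Cl)cc2)n2ncnc2N1`, differs from compound 2 by chloro in place of nitro on an aromatic carbon. Among the compounds with values here, the only measured step, no change at the digits printed from compound 1 to compound 2 (within the scatter), touches the same aromatic carbon and was flat. Within the data shown here, no measured step involves a chloro group. On that basis compound 3 is expected to stay within the scatter, as no change at the digits printed from compound 2 to compound 3 (within the scatter). The estimate for compound 3 is 25 ug/mL, with a range from 12 ug/mL to 50 ug/mL.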

Compound 3, half-maximal cytotoxic concentration: 20 ug/mL
Compound 3: middle estimate off by 1.3-fold (0.10 log units), on the high side; the range from low to high includes it.
By their numbers in this assay, from the lowest: compounds 3, 1 and 2 (each within the scatter of the next).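

In this assay, a second replacement at the same aromatic carbon gives a 1.3-fold lower number from compound 2 to compound 3 (0.10 log units; within the scatter) and chloro set against the parent hydrogen gives a 1.3-fold lower number from compound 1 to compound 3 (0.10 log units; within the scatter) for this 4-chlorophenyl compound. Hydrogen, nitro and chloro at this carbon therefore all read within the scatter of one another, so the flat result now extends from nitro to a halogen, in these three compounds only. Nothing at hand explains this flat reading.

From the compounds shown here alone, whether it would hold for an amine or a carboxylic acid at this carbon remains open. So does the effect of any change elsewhere on the shared core.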